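Swapping a fluorophenol for a dihydroxyphenyl hydrazone

This account rests on a few compounds, and the source may have more. Where it says the series, first, only, none or still open, it means among the compounds named here.

Going by the values given here, compound 2 `Cc1c(C(=O)N/N=C\c2cc(F)ccc2O)oc2cccc(O)c12` gives 3170 nM in a functional assay on PC-3 cells (Homo sapiens) for inhibition (on this read-out lower numbers stand for stronger inhibition and higher numbers for weaker inhibition), the lowest of the two numbers so far, while compound 1 `Cc1c(C(=O)N/N=C\c2c(O)cccc2F)oc2cccc(O)c12` gives 8050 nM. Among the compounds with values here, the single measured step, a 2.5-fold lower number from compound 1 to compound 2 (0.40 log units; beyond the scatter), rearranged the substituents on the same aromatic ring. Compound 3 `Cc1c(C(=O)N/N=C\c2ccc(O)cc2O)oc2cccc(O)c12` carries 2,4-dihydroxyphenyl in place of 5-fluoro-2-hydroxyphenyl on a carbon with a double bond to nitrogen. Within the data shown here, this again reworks that ring, yet no measured pair shows a fluorine giving way to a hydroxyl, so for compound 3 the step is expected to stay within the scatter, a 1.1-fold lower number from compound 2 to compound 3 (0.02 log units; within the scatter). Compound 3 is therefore estimated at 3000 nM, between 1000 nM and 9000 nM.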

Compound 3, half-maximal inhibitory concentration: 14800 nM
Compound 3: middle estimate off by 4.9-fold (0.69 log units), on the low side, and the stated range ends below it.
By their numbers in this assay, from the lowest: compound 2; then compounds 1 and 3 (each within the scatter of the next).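

In this assay, going by these compounds alone, this is the first pair in which a fluorine gives way to a hydroxyl on the ring at this position, and the change is not neutral: a 4.7-fold higher number from compound 2 to compound 3 (0.67 log units; beyond the scatter). The other step, a 1.8-fold higher number from compound 1 to compound 3 (0.26 log units; within the scatter), leaves 2,4-dihydroxyphenyl and 2-fluoro-6-hydroxyphenyl indistinguishable, so only 5-fluoro-2-hydroxyphenyl stands apart among the three. No available evidence explains this difference. Going by these compounds, it remains open whether an amine or a methoxy group in place of the second hydroxyl would match compound 2 or compound 3.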